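A Vinyl Quaternary Ammonium Analogue Among Weak Inhibitors

A few compounds are considered here, and "the series" means these few. Any claim that something is new, unique, unknown or untested is made for them only; others in the source may bear on it.

Compound 1 `CC[N+](C)(CC)CCCC(=O)[O-]` carries two ethyl groups and a methyl on its quaternary nitrogen, and in an assay for inhibition of gamma-butyrobetaine dioxygenase (Homo sapiens), read by HPLC, with stated times of 15 min and 30 min (on this read-out higher numbers stand for weaker inhibition and lower numbers for stronger inhibition), compound 1 gives 100000 nM. Compound 2 `C[N+](C)(CCCC(=O)[O-])CC1CCC1` gives in this assay only a limit, > 1000000 nM. Compound 3 `CCC[N+](C)(C)CCCC(=O)[O-]` likewise gives in this assay only a limit, > 1000000 nM. The step that the two limits leave unreadable from compound 2 to compound 3 therefore cannot be sized, since both of its ends lie at the limit of > 1000000 nM in this assay, at which 2 of the 3 values shown sit. Compound 4 `C=C[N+](C)(C)CCCC(=O)[O-]` differs from compound 3 by vinyl in place of propyl on an amine nitrogen. No measured step touches a vinyl group, and the only step that alters a substituent on the nitrogen is unreadable, so no direction can be drawn from the numbers shown. Compound 4 is expected to stay weak in this assay, with an estimated value near 1000000 nM, between 200000 nM and 5000000 nM. The step of a number no higher from compound 3 to compound 4 (the limit leaves the size open) is expected to remain within the scatter.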

Compound 4, half-maximal inhibitory concentration: 127000 nM
Estimate against measurement, compound 4: 7.9-fold (0.90 log units) above; the whole stated range lies above it.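

Vinyl in place of propyl on an amine nitrogen gives an at least 7.8-fold lower number from compound 3 to compound 4 (0.89 log units; beyond the scatter) in this assay. This shows that a change of this substituent can move the read-out, which the earlier step between two limits could not show. The size of the step stays open, as the value of compound 3 is only a limit: the limit of > 1000000 nM in this assay, at which 2 of the 4 values shown sit.

The compounds shown do not tell whether the double bond or the shorter chain goes with this step. A single ethyl group in place of vinyl, or an allyl group, would bear on that question.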